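Aryl extension of the ethyl chain in compound 1

The source may hold more compounds than are shown below. What is called first, only, known or untested is meant among the compounds shown, and "the series" means these compounds.

Within the data shown here, compound 1 `CCc1nc(N)c2nn(-c3ccccc3)cc2n1` gives 90 nM in an assay on CHO cells for displacement of a labelled ligand from adenosine receptor A1 (Homo sapiens), read by scintillation counting (on this read-out higher numbers stand for weaker inhibition and lower numbers for stronger inhibition), the lower of the two numbers measured so far. Compound 2 `Nc1nc(/C=C/c2ccccc2)nc2cn(-c3ccccc3)nc12` gives 480 nM in this assay; the step of a 5.3-fold higher number from compound 1 to compound 2 (0.73 log units; beyond the scatter) shows that 2-phenylethenyl in place of ethyl weakens inhibition. Compound 3 `COc1ccc(CCc2nc(N)c3nn(-c4ccccc4)cc3n2)cc1` differs from compound 1 by 4-methoxyphenyl in place of hydrogen on a saturated chain carbon, two bonds along the chain from an aromatic carbon. Among the measured compounds shown here, only the step from compound 1 to compound 2 bears on this change; it is modest and beyond the scatter, so a weakening of similar or smaller size is expected, and the estimate amounts to a 2.8-fold higher number from compound 1 to compound 3 (0.44 log units; beyond the scatter). Compound 3 is thus expected to give 250 nM, in the range 80 nM to 800 nM.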

Compound 3, inhibition constant: 380 nM
For compound 3 the middle estimate is 1.5-fold (0.18 log units) below the measured one; the range from low to high includes it.
By their numbers in this assay, from the lowest: compound 1; then compounds 3 and 2 (each within the scatter of the next).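

In this assay, 4-methoxyphenyl in place of hydrogen on a saturated chain carbon, two bonds along the chain from an aromatic carbon, gives a 4.2-fold higher number from compound 1 to compound 3 (0.63 log units; beyond the scatter) and so places a weakening on a saturated chain as well. The weakening seen with the 2-phenylethenyl of compound 2 is therefore not confined to that unsaturated group. No measurement on hand explains this loss. On these data alone, it remains open whether an unsubstituted phenyl, a longer chain, an amine or a carboxylic acid in place of 4-methoxyphenyl would bring the number back towards that of compound 1.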